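Diethylamino in place of ethyl: cytotoxicity notes

The source may report more compounds than this note shows. Statements on the series, on what has been measured and on what is new or still open speak of the compounds shown alone.

Measured compounds:
compound 1 `CCc1ccc(C(=O)NNc2c(Br)cccc2Br)cc1` — > 100000 nM
compound 2 `O=C(NNc1c(Br)cccc1Br)c1ccc2ccccc2c1` — > 100000 nM
compound 3 `CCc1ccc(C(=O)NNc2c(Br)cc(Br)cc2Br)cc1` — > 100000 nM

Compound 1 stands at a limit in a toxicity assay on MDCK cells (Canis lupus familiaris) for cytotoxicity, read by CCK-8 assay, with a stated time of 48 h; a higher number here means that more compound is tolerated, a lower number that less compound is tolerated: compound 1 gives > 100000 nM, which is a limit of the assay and not a number. Compound 2 likewise gives > 100000 nM, a limit. Compound 3 gives > 100000 nM, again a limit. Among the measured compounds shown here, the single step between measured compounds, a step that the two limits leave unreadable from compound 1 to compound 3, therefore cannot be read in size or direction, and the whole picture rests on (the limit of > 100000 nM in this assay, at which 3 of the 3 values shown sit).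

Compound 4 `CCN(CC)c1ccc(C(=O)NNc2c(Br)cccc2Br)cc1` differs from compound 1 by diethylamino in place of ethyl on an aromatic carbon. For the measured compounds named here, no measured step touches this exchange of one group for the other, and the one step that exists is unreadable, so nothing measured argues for a change beyond the scatter in this assay. Compound 4 is expected to sit at the limit as well, with an estimate of 150000 nM and a range of 60000 nM to 400000 nM. The expected step that the limit leaves unreadable from compound 1 to compound 4 is meant as no change beyond scatter, given that compound 1 gives > 100000 nM.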

Compound 4, half-maximal cytotoxic concentration: 34000 nM
Compound 4: middle estimate off by 4.4-fold (0.64 log units), on the high side; the whole stated range lies above it.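

In this assay, diethylamino in place of ethyl, on an aromatic carbon para to a large group, gives an at least 2.9-fold lower number from compound 1 to compound 4 (0.46 log units; beyond the scatter). Among the compounds shown here, compound 4, at 34000 nM, thus carries the only value that is a number rather than a limit, and this is the first readable sign that the group at this position can change how much compound is tolerated; the earlier step, bromo in place of hydrogen, cannot be read. The step has a lower bound but no known full size because compound 1 has no number of its own: the limit of > 100000 nM in this assay, at which 3 of the 4 values shown sit.

As far as these compounds go, it remains open whether dimethylamino or a longer chain such as butyl at the same place would lower the number as well. Also open, from the compounds shown here alone, is whether the same exchange would give a comparable step on the core of compound 3.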